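Removing the Dimethylamino Group: What to Expect

The compounds below may be only part of what the source reports. "The series", "measured", "known", "first", "only" and "open" are said of these compounds alone.

Compound 1, `O=C1C(=Cc2ccc(O)cc2)C(=O)N(c2ccc(Cl)cc2)N1c1ccc(Cl)cc1`: in a functional assay on MCF7 cells (Homo sapiens) for cytotoxicity, read by MTT assay, with a stated time of 72 h (a higher number here means a weaker inhibitor, a lower number a stronger inhibitor), compound 1 gives 23200 nM.
Compound 2, `CN(C)c1ccc(C=C2C(=O)N(c3ccc(Cl)cc3)N(c3ccc(Cl)cc3)C2=O)cc1`: for compound 2 this assay reports only a limit, > 128000 nM.
Compound 3, `O=C1C(=C/C=C/c2ccccc2)C(=O)N(c2ccc(Cl)cc2)N1c1ccc(Cl)cc1`: compound 3 gives 9400 nM.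

Compound 2 thus stands at the weak end of the three, and because the limit of > 128000 nM in this assay, at which 1 of the 3 values shown sits, is all that is known of it, every step away from it is only a bound. Compound 4, `O=C1C(=Cc2ccccc2)C(=O)N(c2ccc(Cl)cc2)N1c1ccc(Cl)cc1`, differs from compound 2 by hydrogen in place of dimethylamino on an aromatic carbon. Within the data shown here, two measured steps bear on this change: an at least 5.5-fold higher number from compound 1 to compound 2 (0.74 log units; beyond the scatter), and an at least 13-fold lower number from compound 2 to compound 3 (1.13 log units; beyond the scatter). Both put compound 2 well behind its neighbours, so a clear drop in the number is expected for compound 4, with the estimated step of an at least 8.5-fold lower number from compound 2 to compound 4 (0.93 log units; beyond the scatter) in this assay. Compound 4 is therefore estimated at 15000 nM, with a range from 5000 nM to 50000 nM.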

Compound 4, half-maximal inhibitory concentration: 20200 nM
The estimate for compound 4 lay 1.3-fold (0.13 log units) below the measured number, and the stated range covers the measured number.
By their numbers in this assay, from the lowest: compound 3; then compounds 4 and 1 (each within the scatter of the next). At a limit, above all of these: compound 2.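

Replacing dimethylamino with hydrogen gives an at least 6.3-fold lower number from compound 2 to compound 4 (0.80 log units; beyond the scatter) in this assay, which remains only a bound because compound 2 is known solely by a limit: the limit of > 128000 nM in this assay, at which 1 of the 4 values shown sits. Hydrogen and hydroxy on this aromatic carbon are not told apart, as a 1.1-fold lower number from compound 1 to compound 4 (0.06 log units; within the scatter) shows, so among the three groups present only dimethylamino stands apart. The edge of 2-phenylethenyl also holds against unsubstituted phenyl, with a 2.1-fold higher number from compound 3 to compound 4 (0.33 log units; beyond the scatter) showing a modest step.

The compounds shown leave open how a primary amine or a methoxy group on this carbon would compare. They also leave open whether a hydroxy group on the phenyl of 2-phenylethenyl would change compound 3.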